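Ethyl to cyclopropyl at an assay limit

A few compounds are considered here, and "the series" means these few. Any claim that something is new, unique, unknown or untested is made for them only; others in the source may bear on it.

Results in an ADME assay on GES1 cells (Homo sapiens) for inhibition, read by MTT assay, with a stated time of 72 h (on this read-out lower numbers stand for stronger inhibition and higher numbers for weaker inhibition), so far
Compound 1 `Cc1cc(Nc2cc(-c3ccccc3)[nH]n2)n2nc(SCc3c(Cl)cccc3Cl)nc2n1` gives 39600 nM
Compound 2 `Cc1cc(Nc2cc(-c3ccccc3)[nH]n2)n2nc(SCc3ccc(Cl)cc3)nc2n1` gives 31800 nM
Compound 3 `CCCSc1nc2nc(C)cc(Nc3cc(-c4ccccc4)[nH]n3)n2n1` gives > 50000 nM

For compound 3 the entry > 50000 nM is a limit of the assay and not a number. Compound 3 therefore stands at the limit of > 50000 nM in this assay, at which 1 of the 3 values shown sits, and its exact position is not known.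

Compound 4 `Cc1cc(Nc2cc(-c3ccccc3)[nH]n2)n2nc(SCC3CC3)nc2n1` shares its core with compound 3. The change is cyclopropyl in place of ethyl on a saturated chain carbon bound to a sulfur so that propyl becomes cyclopropylmethyl.

Three measured steps changed the group at this same place. They read a 1.2-fold lower number from compound 1 to compound 2 (0.10 log units; within the scatter) then an at least 1.2-fold higher number from compound 1 to compound 3 (0.10 log units; that floor lies within the scatter) and finally an at least 1.5-fold higher number from compound 2 to compound 3 (0.19 log units; that floor lies within the scatter) and none of them goes beyond the scatter. Two of these are only floors, so they leave the true size open.

On that evidence, no step beyond the scatter is expected in this assay for this change, and another limit instead of a number would be no surprise. The expected step, as an estimate, is a number no higher from compound 3 to compound 4 (the limit leaves the size open) and no more should be read into it. The estimate for compound 4 is 50000 nM with an expected range from 28000 nM to 90000 nM as the plausible span.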

Compound 4, half-maximal inhibitory concentration: > 50000 nM
Compound 4: only a limit was reported; the forecaster's own chance of this, stated with the estimate: 55%; the middle value lies on the limit itself.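

In this assay compound 4 gives > 50000 nM, which is a limit of the assay and not a number, and the step that links it to compound 3 cannot be read. From the compounds shown here alone, the new information is that swapping the open propyl chain for cyclopropylmethyl, which adds a small ring on the saturated chain carbon bound to the sulfur, does not bring the result back inside the measurable range, so the limit is now shared: the limit of > 50000 nM in this assay, at which 2 of the 4 values shown sit. Against the two chlorine-bearing compounds the result reads as an at least 1.5-fold higher number from compound 2 to compound 4 (0.19 log units; that floor lies within the scatter) and as an at least 1.2-fold higher number from compound 1 to compound 4 (0.10 log units; that floor lies within the scatter), so neither floor separates compound 4 from compound 1 or compound 2, and the true size of both steps stays open.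

The compounds shown leave open how far compound 3 and compound 4 lie past the limit, and whether any group at this place can shift the number beyond the scatter. A longer chain, or a chain ending in an amine or a carboxylic acid, would test that question at this same place on the shared core.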